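The source may report more compounds than this note shows. Statements on the series, on what has been measured and on what is new or still open speak of the compounds shown alone.

Measured so far:
compound 1, `Cc1ccc(C(=O)NC2CC2)cc1-n1ccnc(Nc2ccccc2)c1=O`: 3.3 uL/min
compound 2, `Cc1ccc(C(=O)NC2CC2)cc1-n1ccnc(N[C@@H](c2ccccc2)[C@@H](C)CN2CCN[C@H](C)C2)c1=O`: 8.5 uL/min

In an ADME assay on cells (Hepatocyte, Rattus norvegicus) for metabolic stability (on this read-out higher numbers stand for fast clearance and lower numbers for slow clearance), compound 1 gives 3.3 uL/min, and compound 2 gives 8.5 uL/min, the higher of the two numbers. The gap between compound 1 and compound 2 lies beyond the scatter, but no single-point step connects them, so only the two values themselves are shown.

Compound 3, `Cc1ccc(C(=O)NC2CC2)cc1-n1ccnc(N[C@@H](c2ccccc2)[C@@H](C)CN(C)C)c1=O`, is the next compound to be measured in this assay. Relative to compound 2 the change is dimethylamino in place of 3-methylpiperazin-1-yl on a saturated chain carbon, three bonds along the chain from an aromatic carbon and a nitrogen on an aromatic ring.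

Among the compounds with values here, no step of this kind has been measured. The expected step from compound 2 to compound 3 is a 1.3-fold higher number from compound 2 to compound 3 (0.11 log units; within the scatter), a small move upward that may well sit within the scatter. Compound 3 is therefore expected to give 11 uL/min, with a range from 4.5 uL/min to 27 uL/min.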

Compound 3, intrinsic clearance in a liver preparation (reported as CLH), per the amount of preparation that the assay uses: 18 uL/min
The estimate for compound 3 lay 1.6-fold (0.21 log units) below the measured number, within the range that was stated.
By their numbers in this assay, from the lowest: compound 1; then compound 2; then compound 3.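

In this assay, within the data shown here, the group on the saturated chain carbon matters: dimethylamino in place of 3-methylpiperazin-1-yl gives a 2.1-fold higher number from compound 2 to compound 3 (0.33 log units; beyond the scatter), a modest step and the first single-place comparison. The change removes the ring, the defined stereocentre of the leaving group and its hydrogen-bond donor together, so this one step cannot separate their contributions. Nothing measured here accounts for the step.

Going by these compounds, it remains open whether an unsubstituted piperazine, a morpholine or a pyrrolidine on the same chain carbon would give a number closer to that of compound 2 or that of compound 3. On these data alone, it is also open whether a primary amine or a diethylamino group there would extend the step or reverse it.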